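A few compounds are considered here, and "the series" means these few. Any claim that something is new, unique, unknown or untested is made for them only; others in the source may bear on it.

Compound 1 `CC(O)(CSc1ccc(C(F)(F)F)cc1)C(=O)Nc1ccc(S(F)(F)(F)(F)F)cc1` and compound 2 `CC(O)(CSc1ccccc1C(F)(F)F)C(=O)Nc1ccc(S(F)(F)(F)(F)F)cc1` share one core and differ in that (2-(trifluoromethyl)phenyl in place of 4-(trifluoromethyl)phenyl on a sulfur). In a functional assay on CWR22R cells (Homo sapiens) for antiproliferative activity, read by propidium iodide staining, with a stated time of 96 h (on this read-out lower numbers stand for stronger inhibition and higher numbers for weaker inhibition), compound 1 gives 14800 nM, while compound 2 gives 13200 nM, which amounts to a 1.1-fold lower number from compound 1 to compound 2 (0.05 log units; within the scatter). Compound 3 `CC(O)(CSc1ccc(OC(F)(F)F)cc1)C(=O)Nc1ccc(S(F)(F)(F)(F)F)cc1` arises from compound 1 through (trifluoromethoxy in place of trifluoromethyl on an aromatic carbon); in this assay compound 3 gives 14900 nM, so that a 1.0-fold higher number from compound 1 to compound 3 (0.00 log units; within the scatter). Compound 4 `CC(O)(CSc1ccccc1OC(F)(F)F)C(=O)Nc1ccc(S(F)(F)(F)(F)F)cc1`, not yet measured, arises from compound 2 through (trifluoromethoxy in place of trifluoromethyl on an aromatic carbon). This change appears twice among the four compounds and is the same kind of change as that from compound 1 to compound 3, the surroundings differing only in that the group sits ortho to a large group in compound 4 but para to a large group in compound 3. Because the earlier step of a 1.0-fold higher number from compound 1 to compound 3 (0.00 log units; within the scatter) stayed within the scatter, a step of similar size is expected here, namely a 1.0-fold lower number from compound 2 to compound 4 (0.01 log units; within the scatter). Compound 4 is therefore estimated to give 13000 nM in this assay, with a likely range from 7000 nM to 25000 nM.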

Compound 4, half-maximal inhibitory concentration: 15000 nM
The estimate for compound 4 lay 1.2-fold (0.06 log units) below the measured number, within the range that was stated.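

Trifluoromethoxy in place of trifluoromethyl gives a 1.1-fold higher number from compound 2 to compound 4 (0.06 log units; within the scatter) in this assay and thus no readable shift on this core. Set beside the earlier step, the exchange behaves alike on both cores: the same change on two cores in this assay, a 1.0-fold higher number (0.00 log units; within the scatter) from compound 1 to compound 3 and a 1.1-fold higher number (0.06 log units; within the scatter) from compound 2 to compound 4, 1.1-fold (0.05 log units) apart, within the scatter of two such steps. This shows that, across these two pairs, the change carried from one core to the other without a readable difference, but with both steps within the scatter it does not show that the change would stay silent on any other core or in any other assay. The compounds shown leave open whether a group of another kind in that place, such as a nitrile, an amine or a carboxylic acid, would shift the number at all. They also leave open whether any change to the amide side of the shared core would do so.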